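Methoxy for methyl on the piperazine aryl cap

A few compounds are considered here, and "the series" means these few. Any claim that something is new, unique, unknown or untested is made for them only; others in the source may bear on it.

Three compounds share one core and differ only in the group on an amine nitrogen in a ring. Compound 1 `CC#CC(CC(=O)O)c1ccc(OCc2ccc(C(=O)N3CCN(Cc4ccccc4)CC3)s2)cc1` carries a benzyl there and in a functional assay on HEK293 cells for agonist activity at Free fatty acid receptor 1 (Homo sapiens), read by fluorescence and calcium flux (on this read-out lower numbers stand for an effect already at smaller amounts and higher numbers for an effect only at larger amounts of compound), compound 1 gives 155 nM. Compound 2 `CC#CC(CC(=O)O)c1ccc(OCc2ccc(C(=O)N3CCN(c4cccnc4)CC3)s2)cc1` carries a pyridin-3-yl, and in this assay compound 2 gives 1140 nM. Compound 3 `CC#CC(CC(=O)O)c1ccc(OCc2ccc(C(=O)N3CCN(c4ccc(C)cc4)CC3)s2)cc1` carries a 4-methylphenyl, and in this assay compound 3 gives 211 nM, the second highest of the three numbers; the change a 1.4-fold higher number from compound 1 to compound 3 (0.13 log units; within the scatter) stays within the scatter, while a 5.4-fold lower number from compound 2 to compound 3 (0.73 log units; beyond the scatter) lies beyond it.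

Compound 4 `CC#CC(CC(=O)O)c1ccc(OCc2ccc(C(=O)N3CCN(c4ccc(OC)cc4)CC3)s2)cc1` is the next step: methoxy in place of methyl on an aromatic carbon. Among the compounds with values here, no measured step swaps methyl for methoxy; the closest comparison is a 1.4-fold higher number from compound 1 to compound 3 (0.13 log units; within the scatter), where one aryl cap replaced another with almost no change. The step from compound 3 to compound 4 is therefore expected to be small, a 1.2-fold higher number from compound 3 to compound 4 (0.07 log units; within the scatter), in no firm direction beyond the scatter. Compound 4 is estimated at 250 nM, with a range from 100 nM to 650 nM.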

Compound 4, half-maximal effective concentration: 289 nM
Compound 4: the middle estimate sits 1.2-fold (0.06 log units) below what was measured, within the range that was stated.
By their numbers in this assay, from the lowest: compounds 1, 3 and 4 (each within the scatter of the next); then compound 2.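

In this assay, within the data shown here, methoxy in place of methyl on an aromatic carbon, para to a large group, gives the first direct reading of this change (a 1.4-fold higher number from compound 3 to compound 4 (0.14 log units; within the scatter)), so the entering oxygen leaves the number within the scatter. The 4-methoxyphenyl cap also stays within the scatter of the benzyl (a 1.9-fold higher number from compound 1 to compound 4 (0.27 log units; within the scatter)) but remains clearly apart from the pyridin-3-yl (a 3.9-fold lower number from compound 2 to compound 4 (0.60 log units; beyond the scatter)), so the gap to compound 2 now holds for two substituted phenyl caps, compound 3 and compound 4. Nothing available explains why the exchange of methyl for methoxy changes so little.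

From the compounds shown here alone, it remains open whether a fluorine, a nitrile or a hydroxyl on the same carbon would also stay within the scatter. Also open, going by these compounds, is whether an amine or a carboxylic acid there would move the number as far as the pyridin-3-yl does.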